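Working notes on an amidine series, compound 2 to compound 3

This account rests on a few compounds, and the source may have more. Where it says the series, first, only, none or still open, it means among the compounds named here.

compound 1 `CNC(=N)Nc1nc(-c2ccc(OC)cc2)c(-c2ccc(OC)cc2)s1`: 62 nM
compound 2 `COc1ccc(-c2nc(/N=C(\N)N(C)C)sc2-c2ccc(OC)cc2)cc1`: 37 nM

Among the compounds with values here, in a functional assay with Oryctolagus cuniculus as the target (a lower number here means a stronger inhibitor, a higher number a weaker inhibitor), compound 2 gives 37 nM, the lowest of the two numbers so far. Compound 1 gives 62 nM, and the step of a 1.7-fold lower number from compound 1 to compound 2 (0.22 log units; within the scatter) lies within the scatter, so the two compounds cannot be ordered. Compound 3 `COc1ccc(-c2nc(/N=C(\N)[N+]3(C)CCCCC3)sc2-c2ccc(OC)cc2)cc1` has not yet been measured. It differs from compound 2 by a group of 7 heavy atoms (6 carbon, 1 nitrogen; one six-membered non-aromatic ring with 1 hetero atom) in place of a group of 3 heavy atoms (2 carbon, 1 nitrogen; no ring), on a carbon with a double bond to nitrogen. Within the data shown here, the only measured step sits at another position and was itself within the scatter, so it offers no firm direction for this change. Compound 3 is expected to give about 90 nM, with a range from 25 nM to 400 nM. This estimate corresponds to an expected step of a 2.4-fold higher number from compound 2 to compound 3 (0.39 log units; beyond the scatter).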

Compound 3, half-maximal inhibitory concentration: > 1000 nM
Compound 3 ended at the assay's limit; the forecaster's own chance of this, stated with the estimate: 5%; at least 11-fold (1.04 log units) between middle value and limit.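

In this assay compound 3 stands at a limit of the assay, not at a number: the limit of > 1000 nM in this assay, at which 1 of the 3 values shown sits. Replacing dimethylamino with the six-membered ring carrying a net charge of +1, on the carbon with a double bond to nitrogen, gives an at least 27-fold higher number from compound 2 to compound 3 (1.43 log units; beyond the scatter), so this place does not accept every replacement. The comparison with the other measured compound gives the same reading: an at least 16-fold higher number from compound 1 to compound 3 (1.20 log units; beyond the scatter).

The ring and the net charge enter together, and the compounds shown do not separate them. As far as these compounds go, how a diethylamino group, with no net charge, would read at this place remains open.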